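The compounds below may be only part of what the source reports. "The series", "measured", "known", "first", "only" and "open" are said of these compounds alone.

Among the measured compounds shown here, compound 1 `NS(=O)(=O)NCC1CCN(c2cc(-c3cccc(Cl)c3)ncn2)CC1` is the only compound of this set with a number in a functional assay on M21 cells (Homo sapiens) for antiproliferative activity, read by sulforhodamine B assay, with a stated time of 48 h (on this read-out lower numbers stand for stronger inhibition of growth and higher numbers for weaker inhibition of growth), where compound 1 gives 62500 nM. Compound 2 `NS(=O)(=O)NCC1CCN(c2cc(-c3ccccc3F)ncn2)CC1` reaches only a limit of this assay, > 100000 nM, which is the limit of > 100000 nM in this assay, at which 1 of the 2 values shown sits. That gives an at least 1.6-fold higher number from compound 1 to compound 2 (0.20 log units; that floor lies within the scatter), a change on the aromatic carbon that bears no connection to the chain. For the measured compounds named here, compound 3 `NS(=O)(=O)NCCC1CCN(c2cc(-c3cccc(Cl)c3)ncn2)CC1` differs from compound 1 by (sulfamoylamino)methyl in place of sulfamoylamino on a saturated chain carbon bound to a saturated ring carbon, a change for which no measured step exists. Compound 3 is therefore expected to stay near compound 1 in this assay, with a 1.1-fold higher number from compound 1 to compound 3 (0.05 log units; within the scatter). The estimate for compound 3 is 70000 nM, between 25000 nM and 200000 nM.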

Compound 3, concentration for 50% growth inhibition: 50700 nM
For compound 3 the middle estimate is 1.4-fold (0.14 log units) above the measured one; low and high end bracket the measured number.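

Among the compounds shown here, this is the first measured step at this place, on a saturated chain carbon bound to a saturated ring carbon; the earlier step changed only the aromatic carbon. In this assay, (sulfamoylamino)methyl in place of sulfamoylamino gives a 1.2-fold lower number from compound 1 to compound 3 (0.09 log units; within the scatter), so the longer chain leaves the number unchanged within the scatter. Nothing shown offers a reason for this result. As far as these compounds go, it remains open how a still longer chain would read here, or an amine or a carboxylic acid in place of the sulfamoylamino end.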